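The source may report more compounds than this note shows. Statements on the series, on what has been measured and on what is new or still open speak of the compounds shown alone.

The measured compounds are:

compound 1, `COc1ccc(F)c([C@H]2CC[C@H](COc3cccc([C@H](C4CC4)[C@@H](F)C(=O)O)c3)CC2)c1`, with 28 nM
compound 2, `COc1ccc(F)c([C@H]2CC[C@H](COc3cccc([C@H](C4CC4)[C@](C)(F)C(=O)O)c3)CC2)c1`, with 6.9 nM

Within the data shown here, compound 2 gives the lower of the two numbers so far in a functional assay on HEK293 cells for agonist activity at Free fatty acid receptor 1 (Rattus norvegicus), read by FLIPR and calcium flux; a higher number here means that more compound is needed for the effect, a lower number that less compound is needed; its nearest neighbour is compound 1, and the single step between them, a 4.1-fold lower number from compound 1 to compound 2 (0.61 log units; beyond the scatter), lies beyond the scatter. Compound 3, `COc1ccc(F)c([C@H]2CC[C@H](COc3cccc([C@H](C4CC4)C(F)(F)C(=O)O)c3)CC2)c1`, has not been measured. It differs from compound 2 in one place: carboxy(difluoro)methyl in place of 1-carboxy-1-fluoroethyl on a saturated chain carbon bound to an aromatic carbon and a saturated ring carbon. Among the measured compounds shown here, the only step that bears on this change is the one from compound 1 to compound 2, in which the methyl was added and the number fell. Here the methyl leaves again, and a second fluorine takes its place, a change for which no measured pair gives a direct reading. The expected outcome is therefore a number that moves back toward that of compound 1, with the second fluorine leaving the direction uncertain. Compound 3 is expected to give 20 nM in this assay, within a range of 6 nM to 60 nM. The expected step is a 2.9-fold higher number from compound 2 to compound 3 (0.46 log units; beyond the scatter).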

Compound 3, half-maximal effective concentration: 34 nM
Estimate against measurement, compound 3: 1.7-fold (0.23 log units) below, within the range that was stated.
By their numbers in this assay, from the lowest: compound 2; then compounds 1 and 3 (each within the scatter of the next).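

In this assay, the exchange of 1-carboxy-1-fluoroethyl for carboxy(difluoro)methyl gives a 4.9-fold higher number from compound 2 to compound 3 (0.69 log units; beyond the scatter), so at this place on the saturated chain carbon bound to an aromatic carbon and a saturated ring carbon, a second fluorine does not preserve the lower number that came with the methyl. The exchange of carboxy(fluoro)methyl for carboxy(difluoro)methyl gives a 1.2-fold higher number from compound 1 to compound 3 (0.08 log units; within the scatter), which shows that among these three compounds, a second fluorine in place of hydrogen leaves the number within the scatter, and only the methyl of compound 2 sets a compound apart. Nothing measured here accounts for this difference between the methyl and the second fluorine.

The compounds shown leave open whether the lower number is specific to methyl or would also appear with an ethyl, a hydroxyl or a chlorine in its place. They also leave open how the opposite configuration of the carbon bearing the methyl and the fluorine would read in this assay, since compound 2 represents only one arrangement.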